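This account rests on a few compounds, and the source may have more. Where it says the series, first, only, none or still open, it means among the compounds named here.

Of the compounds shown here, two built on one shared core have so far been measured in an in vivo ADME assay on the whole organism (strain Sprague-Dawley) for pharmacokinetics, with Rattus norvegicus as the target, at a dose of 10 mg/kg by the oral route; on this read-out lower numbers stand for slow clearance and higher numbers for fast clearance. Compound 1 `Nc1ccc(CN2CCN(c3ccc(N4C[C@H](Cn5ccnn5)OC4=O)cc3F)CC2)cc1` gives 54.4 mL/min/kg in this assay. Within the data shown here, compound 2 `O=C1O[C@@H](Cn2ccnn2)CN1c1ccc(N2CCN(Cc3ccc([N+](=O)[O-])o3)CC2)c(F)c1` gives 18 mL/min/kg in this assay, the lowest of the two numbers; the only measured step, a 3.0-fold lower number from compound 1 to compound 2 (0.48 log units; beyond the scatter), separates them. Compound 3 `O=C1O[C@@H](Cn2ccnn2)CN1c1ccc(N2CCN(Cc3cccc([N+](=O)[O-])c3)CC2)c(F)c1` is the next compound to be measured, and it differs from compound 2 in one place: 3-nitrophenyl in place of 5-nitrofuran-2-yl on a saturated chain carbon bound to an amine nitrogen in a ring. Among the measured compounds shown here, no measured step covers this exact exchange. For the measured compounds named here, the one step available swapped a 4-aminophenyl for a 5-nitrofuran-2-yl and shows how far that single change moved the number, but it says nothing about how two nitro-bearing aromatic rings compare with each other. With no direct anchor for the direction, the expectation for compound 3 is a step no larger than the measured one and most likely within the scatter, a 1.3-fold higher number from compound 2 to compound 3 (0.12 log units; within the scatter). The clearance of compound 3 is therefore estimated at 24 mL/min/kg, with a range from 10 mL/min/kg to 55 mL/min/kg, to be compared with the measurement once it is made.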

Compound 3, clearance: 11.7 mL/min/kg
For compound 3 the middle estimate is 2.1-fold (0.31 log units) above the measured one; the range from low to high includes it.
By their numbers in this assay, from the lowest: compounds 3 and 2 (each within the scatter of the next); then compound 1.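

In this assay, putting 3-nitrophenyl in place of 5-nitrofuran-2-yl on the saturated chain carbon bound to the ring amine nitrogen gives a 1.5-fold lower number from compound 2 to compound 3 (0.19 log units; within the scatter) and stays within the scatter, so on this read-out the five-membered ring with one hetero atom and the six-membered ring of carbon only cannot be told apart at this position. The earlier step, a 3.0-fold lower number from compound 1 to compound 2 (0.48 log units; beyond the scatter), could have been specific to the furan ring, but a 4.6-fold lower number from compound 1 to compound 3 (0.67 log units; beyond the scatter) also lies beyond the scatter and points the same way, so among these three compounds the lower clearance relative to the 4-aminophenyl compound does not depend on the furan ring. Nothing available here explains why the numbers fall as they do.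

What the compounds leave open is whether the nitro group itself matters, as the 4-aminophenyl of compound 1 and the 3-nitrophenyl of compound 3 differ both in the group carried and in where it sits on the ring. A plain phenyl or a phenyl carrying a nitrile on the same carbon would help to separate those two differences.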